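Defining a Ring Stereocentre: Compound 1 to Compound 3

The source may hold more compounds than are shown below. What is called first, only, known or untested is meant among the compounds shown, and "the series" means these compounds.

Compound 1 `O=C(O)CC/C=C\CO[C@H]1C(OCc2ccc(-c3ccccc3)cc2)CC[C@@H]1N1CCCCCC1` has been tested in a functional assay on blood for antagonist activity at thromboxane A2 receptor (Homo sapiens) (a lower number here means tighter binding, a higher number weaker binding), where compound 1 gives 12.6 nM. Among the measured compounds shown here, of the two compounds measured so far, compound 1 has the higher number. For the measured compounds named here, its only neighbour is compound 2 `CS(=O)(=O)Nc1ccccc1-c1ccc(COC2CC[C@H](N3CCCCCC3)[C@H]2OC/C=C\CCC(=O)O)cc1`, which carries a methanesulfonamido group in place of a hydrogen on an aromatic carbon; in this assay compound 2 gives 10 nM, and the step of a 1.3-fold lower number from compound 1 to compound 2 (0.10 log units; within the scatter) is too small to count as a real change.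

Compound 3 `O=C(O)CC/C=C\CO[C@H]1[C@@H](OCc2ccc(-c3ccccc3)cc2)CC[C@@H]1N1CCCCCC1` is the next compound. (the two compounds have the same atoms and bonds; at least one stereo element is drawn with a configuration in one of them and without one in the other: 1 of 4 stereo elements differ; a stereocentre at a saturated ring carbon is drawn without a configuration in compound 1 and S in compound 3). Nothing else is altered. Going by the values given here, no measured step in this set touches a stereocentre; the one step that exists, a 1.3-fold lower number from compound 1 to compound 2 (0.10 log units; within the scatter), concerns a group on an aromatic carbon and offers no guide here. Drawing a configuration where none was drawn before may mean that compound 3 is a single isomer of material that compound 1 represented with that centre left open, so the number could move either way, but most likely by little. For compound 3 the dissociation constant is therefore expected to be 9 nM, within a range of 3 nM to 30 nM. The expected step of a 1.4-fold lower number from compound 1 to compound 3 (0.15 log units; within the scatter) is estimated to lie within the scatter.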

Compound 3, dissociation constant: 5.01 nM
The estimate for compound 3 lay 1.8-fold (0.25 log units) above the measured number; measured number inside the range.
By their numbers in this assay, from the lowest: compounds 3, 2 and 1 (each within the scatter of the next, the first and the last beyond it).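

In this assay, among the compounds shown here, drawing the saturated ring carbon as S gives a 2.5-fold lower number from compound 1 to compound 3 (0.40 log units; beyond the scatter), which makes this the only step in the set so far that lies beyond the scatter, even though no atom or bond has changed. Swapping a hydrogen for a methanesulfonamido group on an aromatic carbon gave no readable change, so this stereocentre is the first position here where a change shows up in the number, though the size of the step is modest. The step cannot be read as a clean comparison of two defined forms, since compound 1 may be a mixture at that centre and its composition is not given, and the only known difference between the two compounds is this: the fact that one of compounds 1 and 3 is drawn with a defined configuration and the other without, at the place where they differ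

The compounds shown leave open how a form drawn as R at this centre would read, and so how much of the number of compound 1 comes from each arrangement. They also leave open whether the S centre would keep its effect with the methanesulfonamido group of compound 2 in place, or with a nitrile or a fluorine on that same aromatic carbon.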